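The source may hold more compounds than are shown below. What is called first, only, known or untested is meant among the compounds shown, and "the series" means these compounds.

Compound 1, `O=C(Nc1ccc(-n2ncc3c(Br)cccc32)cc1)Nc1ccc(Cl)c(C(F)(F)F)c1`, gives 2300 nM in a functional assay on A549 cells (Homo sapiens) for cytotoxicity, read by MTT assay, with a stated time of 72 h; on this read-out higher numbers stand for weaker inhibition and lower numbers for stronger inhibition.
Compound 2, `Cc1cccc2c1cnn2-c1ccc(NC(=O)Nc2ccc(Cl)c(C(F)(F)F)c2)cc1`, gives 5500 nM in this assay.
Compound 3, `O=C(Nc1ccc(-n2ncc3ccccc32)cc1)Nc1ccc(Cl)c(C(F)(F)F)c1`, gives 9900 nM in this assay.

Of the three measured compounds, compound 3 carries the highest number in this assay; the two steps that lead up to it are a 1.8-fold higher number from compound 2 to compound 3 (0.26 log units; within the scatter) and a 4.3-fold higher number from compound 1 to compound 3 (0.63 log units; beyond the scatter). Compound 4, `CNc1cccc2c1cnn2-c1ccc(NC(=O)Nc2ccc(Cl)c(C(F)(F)F)c2)cc1`, has not yet been measured. It differs from compound 3 by methylamino in place of hydrogen on an aromatic carbon. Among the compounds with values here, two measured steps touch this same position: from compound 1 to compound 3, where bromo was replaced by hydrogen, the number rose by a 4.3-fold higher number from compound 1 to compound 3 (0.63 log units; beyond the scatter); from compound 2 to compound 3, where methyl was replaced by hydrogen, it rose by a 1.8-fold higher number from compound 2 to compound 3 (0.26 log units; within the scatter). Both substituents at this position therefore gave lower numbers than hydrogen, one modestly and one within the scatter. A methylamino group is expected to behave in the same sense, with a step of about a 2.0-fold lower number from compound 3 to compound 4 (0.30 log units; within the scatter). Compound 4 is thus estimated at 5000 nM, with a range from 2000 nM to 12000 nM.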

Compound 4, half-maximal inhibitory concentration: 4900 nM
The estimate for compound 4 lay 1.0-fold (0.01 log units) above the measured number; the measured number falls inside the stated range.
By their numbers in this assay, from the lowest: compound 1; then compounds 4, 2 and 3 (each within the scatter of the next, the first and the last beyond it).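

In this assay, methylamino in place of hydrogen on this aromatic carbon gave a 2.0-fold lower number from compound 3 to compound 4 (0.31 log units; beyond the scatter), so a substituent containing nitrogen, with one hydrogen-bond donor, also lowers the number relative to hydrogen, as bromo does, whereas the methyl step stays within the scatter. Methylamino in place of methyl gave only a 1.1-fold lower number from compound 2 to compound 4 (0.05 log units; within the scatter), so these two groups cannot be told apart here, while methylamino in place of bromo gave a 2.1-fold higher number from compound 1 to compound 4 (0.33 log units; beyond the scatter), leaving bromo with the lowest number at this position. No measurement shown here explains these differences.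

The compounds shown leave open whether an unsubstituted amine, a dimethylamino group or a longer chain such as ethylamino would follow methylamino at this carbon. They also leave open whether chloro or fluoro would follow bromo.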